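A Triazole in Place of Methylpiperazine: Expected Inhibition

The source may hold more compounds than are shown below. What is called first, only, known or untested is meant among the compounds shown, and "the series" means these compounds.

Measured compounds in a functional assay on MDA-MB-231 cells (Homo sapiens) for inhibition, read by sulforhodamine B assay, tested at 10 uM; on this read-out lower numbers stand for less inhibition and higher numbers for more inhibition at the one concentration tested (going by the name of the read-out):
- compound 1 `CN1CCN(c2ccc(C3=NN(S(C)(=O)=O)C(c4ccc(N(C)C)cc4)C3)cc2)CC1`: 0.6%
- compound 2 `CN1CCN(c2ccc(C3=NN(S(=O)(=O)c4ccc(Br)cc4)C(c4ccc(N(C)C)cc4)C3)cc2)CC1`: 23.7%
- compound 3 `CN1CCN(c2ccc(C3=NN(S(=O)(=O)c4ccc(OC(F)(F)F)cc4)C(c4ccc(N(C)C)cc4)C3)cc2)CC1`: 10.6%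

Compound 3 sits between its two neighbours: the step of a number 10 percentage points higher from compound 1 to compound 3 (within the scatter) lies within the scatter, while the step of a number 13.1 percentage points lower from compound 2 to compound 3 (beyond the scatter) lies beyond it, so only compound 2 is clearly set apart from compound 3. All three measured steps, including a number 23.1 percentage points higher from compound 1 to compound 2 (beyond the scatter), vary the group on the sulfonyl sulfur or a substituent on that aryl ring.

Compound 4 `CN(C)c1ccc(C2CC(c3ccc(-n4cncn4)cc3)=NN2S(=O)(=O)c2ccc(OC(F)(F)F)cc2)cc1` differs from compound 3 elsewhere: 1H-1,2,4-triazol-1-yl in place of 4-methylpiperazin-1-yl on an aromatic carbon. No measured step touches this part of the shared core, so nothing shown speaks to the size or direction of this change. The soundest expectation is therefore a step of about a number 1.4 percentage points higher from compound 3 to compound 4 (within the scatter), that is, no change beyond the scatter, with a wide margin of uncertainty in both directions.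

On that basis compound 4 is estimated at 12% in this assay, with a range from 0% to 35%.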

Compound 4, a percentage reported as inhibition, at one concentration (the size of the read-out at that concentration, not a potency): 18.5%
For compound 4 the middle estimate is 6.5 percentage points below the measured one, and the stated range covers the measured number.
By their numbers in this assay, from the lowest: compounds 1, 3, 4 and 2 (each within the scatter of the next, the first and the last beyond it).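

Until compound 4, every compound carried 4-methylpiperazin-1-yl on this aromatic carbon, so the effect of changing that group could not be read. In this assay, putting 1H-1,2,4-triazol-1-yl in its place gives a number 7.9 percentage points higher from compound 3 to compound 4 (within the scatter) and so shows no clear change. At this position and with this sulfonyl group, a five-membered aromatic ring can therefore stand in for a six-membered non-aromatic ring without a difference that stands out from the usual scatter, though nothing at hand helps to explain this result.

From the compounds shown here alone, how a morpholine ring or a carboxylic acid would read at this position remains open. So does whether 1H-1,2,4-triazol-1-yl would give a similar step alongside the 4-bromophenyl group of compound 2 or the methyl group of compound 1.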